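Head-group swaps on the hydrophilic tail of the shared core

The source may hold more compounds than are shown below. What is called first, only, known or untested is meant among the compounds shown, and "the series" means these compounds.

Measured compounds:
- compound 1, `Cc1cc(-n2cc(C(=O)Nc3cc(F)cc(F)c3)c(=O)c3ccc(N(C)C)nc32)ccc1OCCCCCCC[N+]1(C)CCCCC1`: 54.4%
- compound 2, `Cc1cc(-n2cc(C(=O)Nc3cc(F)cc(F)c3)c(=O)c3ccc(N(C)C)nc32)ccc1OCCCCCCC[n+]1ccccc1`: 55%
- compound 3, `CN(C)c1ccc2c(=O)c(C(=O)Nc3cc(F)cc(F)c3)cn(-c3ccc(OCCCCCCC[n+]4ccccc4)c(Cl)c3)c2n1`: 21.4%

In an assay on LX2 cells for inhibition of COL1A1 promoter (Homo sapiens), read by a luciferase reporter, with a stated time of 24 h, tested at 50 uM (a lower number here means a weaker effect, a higher number a stronger effect of the compound at the concentration tested), compound 2 gives 55%, the top number of the three, but its separation from compound 1 is only a number 0.6 percentage points higher from compound 1 to compound 2 (within the scatter), so the two cannot be told apart; compound 3 alone sits clearly lower, through the step of a number 33.6 percentage points lower from compound 2 to compound 3 (beyond the scatter).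

Compound 4, `Cc1cc(-n2cc(C(=O)Nc3cc(F)cc(F)c3)c(=O)c3ccc(N(C)C)nc32)ccc1OCCCCCCC[N+]1(C)CCN(C)CC1`, has not yet been measured. It differs from compound 2 as follows: a group of 8 heavy atoms (6 carbon, 2 nitrogen; one six-membered non-aromatic ring with 2 hetero atoms) in place of a group of 6 heavy atoms (5 carbon, 1 nitrogen; one six-membered aromatic ring with 1 hetero atom), on a saturated chain carbon, seven bonds along the chain from an oxygen on an aromatic ring

For the measured compounds named here, of the two measured steps, only the one from compound 1 to compound 2 touches the same place, the charged head at the end of the seven-bond chain, and it was a number 0.6 percentage points higher from compound 1 to compound 2 (within the scatter), that is, no change beyond the scatter. The step from compound 2 to compound 3 is at a different place, the substituent on the aromatic ring, and so tells nothing direct about the head group. With one head-group swap having left this assay unchanged, the expected step for compound 4 is a number 3 percentage points lower from compound 2 to compound 4 (within the scatter), no change beyond the scatter in either direction. The estimate for compound 4 in this assay is therefore 52%, with a range from 36% to 66%.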

Compound 4, a percentage reported as inhibition, at one concentration (the size of the read-out at that concentration, not a potency): 32%
Compound 4: middle estimate off by 20 percentage points, on the high side; measured number outside the range, below it.
By their numbers in this assay, from the lowest: compound 3; then compound 4; then compounds 1 and 2 (each within the scatter of the next).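

In this assay the charged head at the end of the chain no longer looks like a neutral place to make changes: placing the six-membered non-aromatic ring with 2 hetero atoms there gives a number 23 percentage points lower from compound 2 to compound 4 (beyond the scatter) and, against the saturated ring head with 1 hetero atom, gives a number 22.4 percentage points lower from compound 1 to compound 4 (beyond the scatter) in the same direction. The earlier swap, a number 0.6 percentage points higher from compound 1 to compound 2 (within the scatter) here, showed only that the aromatic and non-aromatic heads with 1 hetero atom cannot be told apart, so among the three heads shown only the one with 2 hetero atoms stands apart, and it is also the only one counted with a hydrogen-bond acceptor. Nothing available on these compounds gives a reason for this step.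

As far as these compounds go, it remains open whether the step follows the second ring nitrogen, the methyl on it or simply the larger group, and a morpholine head or a piperazine head lacking that methyl would help separate these. From the compounds shown here alone, it is also open whether the same head-group step appears with chloro in place of methyl on the aromatic carbon, or with a longer chain.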